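Swapping a piperidine-bearing chain for a pyridylmethyl amine

The source may report more compounds than this note shows. Statements on the series, on what has been measured and on what is new or still open speak of the compounds shown alone.

Measured so far in an assay on HEK293 cells for inhibition of Steryl-sulfatase (Homo sapiens), tested at 1 uM; a lower number here means a weaker effect, a higher number a stronger effect of the compound at the concentration tested:
Compound 1 `CCN(Cc1ccccn1)c1ccc(C(=O)N2CCc3ccc(OS(N)(=O)=O)cc3C2)cc1` gives 87.7%.
Compound 2 `CC(C)CCN(CCC(C)C)c1ccc(C(=O)N2CCc3ccc(OS(N)(=O)=O)cc3C2)cc1` gives 90.8%.
Compound 3 `CN(CCN1CCCCC1)c1ccc(C(=O)N2CCc3ccc(OS(N)(=O)=O)cc3C2)cc1` gives 26.8%.

Compound 3 stands lowest of the three, its nearest neighbour being compound 1 and the furthest compound 2, both beyond the scatter. Compound 4 `CCN(Cc1ccncc1)c1ccc(C(=O)N2CCc3ccc(OS(N)(=O)=O)cc3C2)cc1` differs from compound 3 in one place: ethyl((pyridin-4-yl)methyl)amino in place of methyl(2-(piperidin-1-yl)ethyl)amino on an aromatic carbon. Within the data shown here, two measured steps bear on this change. a number 60.9 percentage points lower from compound 1 to compound 3 (beyond the scatter) and a number 64 percentage points lower from compound 2 to compound 3 (beyond the scatter) both show large falls once methyl(2-(piperidin-1-yl)ethyl)amino entered, whereas a number 3.1 percentage points higher from compound 1 to compound 2 (within the scatter) shows the other two side groups behaving alike. Compound 4 carries a group resembling that of compound 1, which gives 87.7%. Compound 4 is therefore expected to show a large upward step, a number 57.2 percentage points higher from compound 3 to compound 4 (beyond the scatter). Compound 4 is estimated at 84%, between 65% and 95%.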

Compound 4, a percentage reported as inhibition, at one concentration (the size of the read-out at that concentration, not a potency) in the Steryl-sulfatase assay: 86.6%
Estimate against measurement, compound 4: 2.6 percentage points below; the range from low to high includes it.
By their numbers in the Steryl-sulfatase assay, from the lowest: compound 3; then compounds 4, 1 and 2 (each within the scatter of the next).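

Moving the ring nitrogen of the pyridine changes little in the Steryl-sulfatase assay (a number 1.1 percentage points lower from compound 1 to compound 4 (within the scatter)), and the diisopentylamino group is also matched (a number 4.2 percentage points lower from compound 2 to compound 4 (within the scatter)). Replacing methyl(2-(piperidin-1-yl)ethyl)amino restores the read-out (a number 59.8 percentage points higher from compound 3 to compound 4 (beyond the scatter)), although the two groups have the same heavy-atom count. In a physicochemical assay for lipophilicity (a higher number here means a more lipophilic compound, a lower number a more polar compound), compound 3 gives 1.93 and compound 4 gives 1.93 on the same scale, so this partition coefficient does not separate them.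

Nothing shown gives a cause for the large gap. Going by these compounds, whether a pyridin-3-yl group or a morpholine-bearing chain would behave like the pyridines or like the piperidine remains open.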